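The source may report more compounds than this note shows. Statements on the series, on what has been measured and on what is new or still open speak of the compounds shown alone.

Measured so far:
- compound 1, `Brc1cccc2c1nnn2CC1CC1`: 7.7 mL/min/g
- compound 2, `Cn1nnc2c(Br)cccc21`: "not determined" (no result reported)

The account follows the step from compound 1 to compound 3. For the measured compounds named here, in an ADME assay on microsomes from liver (Mus musculus, strain NMRI) for metabolic stability, tested at 2.5 uM (on this read-out higher numbers stand for fast clearance and lower numbers for slow clearance), compound 1 gives 7.7 mL/min/g, and this is the only number in hand. Compound 2, `Cn1nnc2c(Br)cccc21`, carries no result in this assay, so it offers no comparison. Compound 1 therefore stands alone; there is no second number to place it against.

Compound 3, `Fc1cc(Br)c2nnn(CC3CC3)c2c1`, differs from compound 1 in one place: fluoro in place of hydrogen on an aromatic carbon. The fluoro enters on an aromatic carbon of a six-membered aromatic ring of carbon only, part of a fused system of two rings, meta to a bromo group, meta to a fused ring and para to a fused ring. Going by the values given here, no step between two measured compounds is available to show how such a change has behaved here, so the expectation rests on compound 1 only. The step of a 1.2-fold lower number from compound 1 to compound 3 (0.07 log units; within the scatter) is expected to be small, within the usual scatter, with no direction claimed. For compound 3 the estimated value in this assay is 6.5 mL/min/g, with a range from 3.2 mL/min/g to 13 mL/min/g.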

Compound 3, intrinsic clearance in a liver preparation (reported as CLH), per the amount of preparation that the assay uses: 5.7 mL/min/g
Beside the measured number, compound 3's estimate is 1.1-fold (0.06 log units) above it, and the stated range covers the measured number.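

Fluoro on this aromatic carbon, meta to the bromo group and para to a fused ring, gives the first step that can be read in this assay, namely a 1.4-fold lower number from compound 1 to compound 3 (0.13 log units; within the scatter), and so compound 1 no longer stands alone. For the compounds shown here, what the earlier compounds could not show is that this position takes a fluoro in place of hydrogen with no difference beyond the usual scatter of this read-out, so the pair gives no sign that this carbon matters for clearance when only this single atom enters. Nothing measured here speaks to why the read-out behaves this way, and with one pair no reason can be offered.

On these data alone, whether this holds for anything larger at the same carbon stays open, since an amine, a carboxylic acid or a longer chain in place of the fluoro could behave quite differently. Equally open, as far as these compounds go, is whether fluoro on the other aromatic carbons of the ring, or a change to the bromo group itself, would also stay within the scatter, as this single step speaks only for this one position and this one change.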